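Replacing the oxanyl ether on the shared core

A few compounds are considered here, and "the series" means these few. Any claim that something is new, unique, unknown or untested is made for them only; others in the source may bear on it.

Three measured compounds share one core and differ only in the group on the oxygen on the aromatic ring. In an assay for inhibition of serine/threonine-protein kinase Sgk1 (Homo sapiens), with stated times of 30 min and 60 min, in the presence of a further agent that is not named here (on this read-out lower numbers stand for stronger inhibition and higher numbers for weaker inhibition), compound 1 `CCOc1nc(-c2ccc(NS(=O)(=O)c3cc(Cl)ccc3F)cc2)nc2[nH]nc(C)c12` gives 23 nM, compound 2 `Cc1n[nH]c2nc(-c3ccc(NS(=O)(=O)c4cc(Cl)ccc4F)cc3)nc(OCC(CO)CO)c12` gives 1 nM, and compound 3 `Cc1n[nH]c2nc(-c3ccc(NS(=O)(=O)c4cc(Cl)ccc4F)cc3)nc(OC3CCOCC3)c12` gives 5 nM. Compound 3 stands second highest of the three numbers: a 4.6-fold lower number from compound 1 to compound 3 (0.66 log units; beyond the scatter), while a 5.0-fold higher number from compound 2 to compound 3 (0.70 log units; beyond the scatter). Compound 4 `Cc1n[nH]c2nc(-c3ccc(NS(=O)(=O)c4cc(Cl)ccc4F)cc3)nc(OCC3CN(C(C)C)C3)c12` carries (1-isopropylazetidin-3-yl)methyl in place of oxan-4-yl on an oxygen on an aromatic ring. Within the data shown here, the steps of a 23-fold lower number from compound 1 to compound 2 (1.36 log units; beyond the scatter) and a 4.6-fold lower number from compound 1 to compound 3 (0.66 log units; beyond the scatter) show that each change away from the ethyl group has so far given a lower number, yet no measured step covers a ring holding nitrogen in this place. Compound 4 is therefore expected to show only a small step to a lower number, a 1.7-fold lower number from compound 3 to compound 4 (0.22 log units; within the scatter), estimated at 3 nM with a range from 1 nM to 10 nM.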

Compound 4, half-maximal inhibitory concentration: 1 nM
Estimate against measurement, compound 4: 3.0-fold (0.48 log units) above, and the stated range covers the measured number.
By their numbers in this assay, from the lowest: compounds 2 and 4 (each within the scatter of the next); then compound 3; then compound 1.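

With a 5.0-fold lower number from compound 3 to compound 4 (0.70 log units; beyond the scatter), the (1-isopropylazetidin-3-yl)methyl group shows that a ring holding nitrogen on this oxygen gives a lower number than oxan-4-yl. The same group shows no change at the digits printed from compound 2 to compound 4 (within the scatter) and a 23-fold lower number from compound 1 to compound 4 (1.36 log units; beyond the scatter), so a number as low as that of compound 2 does not require the hydroxyl groups of 3-hydroxy-2-(hydroxymethyl)propyl. No measurement given here accounts for this result.

The compounds shown cannot separate the contribution of the ring nitrogen from that of its isopropyl group. Going by these compounds, what an open-chain amine or a carboxylic acid on this oxygen would give remains open.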